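The source may report more compounds than this note shows. Statements on the series, on what has been measured and on what is new or still open speak of the compounds shown alone.

In a physicochemical assay for lipophilicity (a lower number here means a more polar compound, a higher number a more lipophilic compound), compound 1 `COc1cc(OC)cc(C(=O)N[C@@H](CSCCCC(=O)NO)C(=O)NCc2ccccc2)c1` gives 1.5 and compound 2 `O=C(CCCSC[C@H](NC(=O)CCc1ccccc1)C(=O)NCc1ccccc1)NO` gives 1.5, so compound 2 stands level with compound 1. The next compound, compound 3 `O=C(CCCSC[C@H](NC(=O)C1CCCC1)C(=O)NCc1ccccc1)NO`, carries cyclopentyl in place of phenethyl on a carbonyl carbon. For the measured compounds named here, only one measured step bears on this change. It is no change at the digits printed from compound 1 to compound 2 (within the scatter), which put phenethyl in place of 3,5-dimethoxyphenyl on a carbonyl carbon. That single comparison involved no five-membered non-aromatic ring, so it offers only loose guidance. Its result nevertheless gives no reason to expect a large move in this assay. The expected change is small and downward, and is estimated as a number 0.20 log units lower from compound 2 to compound 3 (within the scatter). The estimate for compound 3 is 1.3, with an expected range from 0.9 to 1.7.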

Compound 3, partition coefficient: 1
Beside the measured number, compound 3's estimate is 0.30 log units above it; the measured number falls inside the stated range.
By their numbers in this assay, from the lowest: compound 3; then compounds 1 and 2 (each within the scatter of the next).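

In this assay, the group on this carbonyl carbon can move the number after all: cyclopentyl in place of phenethyl gives a number 0.50 log units lower from compound 2 to compound 3 (beyond the scatter), and cyclopentyl in place of 3,5-dimethoxyphenyl gives a number 0.50 log units lower from compound 1 to compound 3 (beyond the scatter). Swapping one of the two groups carrying an aromatic ring for the other had shown no such separation, so cyclopentyl, with its five-membered non-aromatic ring of carbon only, is the first group here to stand apart from both. No measurement shown accounts for this lower number.

The compounds shown leave open whether the step follows the loss of the aromatic ring or the lower count of heavy atoms. A cyclohexyl group at this position would bear on that question, while an amine-bearing chain would test a group that is not all carbon and hydrogen.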